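Compound 4: expected effect of 2,4-dichlorobenzyl in place of benzyl

This account rests on a few compounds, and the source may have more. Where it says the series, first, only, none or still open, it means among the compounds named here.

Measured so far in a functional assay on NCI-H460 cells (Homo sapiens) for cytotoxicity, read by MTT assay, with a stated time of 72 h; on this read-out higher numbers stand for weaker inhibition and lower numbers for stronger inhibition:
compound 1 `CC1CCN(Cc2ccc3nc(NC(=O)N/N=C/c4cn(Cc5ccc(Cl)cc5Cl)c5ccccc45)sc3c2)CC1`, 1660 nM
compound 2 `CN(C)Cc1ccc2nc(NC(=O)N/N=C/c3cn(Cc4ccccc4Cl)c4ccccc34)sc2c1`, 1600 nM
compound 3 `CN(C)Cc1ccc2nc(NC(=O)N/N=C/c3cn(Cc4ccccc4)c4ccccc34)sc2c1`, 400 nM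

Compound 3 stands lowest of the three numbers; compound 2 is nearest and compound 1 furthest, both beyond the scatter. Compound 4 `CN(C)Cc1ccc2nc(NC(=O)N/N=C/c3cn(Cc4ccc(Cl)cc4Cl)c4ccccc34)sc2c1` differs from compound 3 by 2,4-dichlorophenyl in place of phenyl on a saturated chain carbon bound to an aromatic nitrogen. For the measured compounds named here, the one measured step that bears on this is a 4.0-fold lower number from compound 2 to compound 3 (0.60 log units; beyond the scatter), where hydrogen replacing a chloro on an aromatic carbon lowered the number; the present change runs the other way, with chloro entering rather than leaving. Compound 1, which also carries 2,4-dichlorobenzyl, shows 1660 nM, close to compound 2. A higher number is therefore expected for compound 4 in this assay, a step of about a 3.8-fold higher number from compound 3 to compound 4 (0.57 log units; beyond the scatter). The estimate for compound 4 is 1500 nM, within 600 nM to 4000 nM.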

Compound 4, half-maximal inhibitory concentration: 950 nM
Estimate against measurement, compound 4: 1.6-fold (0.20 log units) above; the measured number falls inside the stated range.
By their numbers in this assay, from the lowest: compound 3; then compounds 4, 2 and 1 (each within the scatter of the next).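

In this assay, 2,4-dichlorobenzyl in place of benzyl gives a 2.4-fold higher number from compound 3 to compound 4 (0.38 log units; beyond the scatter), so compound 3, with plain benzyl, stays lowest against both chlorinated benzyl compounds. Adding the further chloro gives a 1.7-fold lower number from compound 2 to compound 4 (0.23 log units; within the scatter), a step within the scatter, so no effect of that chloro can be read. With 2,4-dichlorobenzyl held constant, dimethylamino in place of 4-methylpiperidin-1-yl gives a 1.7-fold lower number from compound 1 to compound 4 (0.24 log units; within the scatter), also within the scatter. Nothing available explains these steps. As far as these compounds go, whether fluoro or methoxy on the benzyl ring would also raise the number remains open, as does the effect of a longer chain in place of benzyl.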